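Phenyl to 1-benzofuran-2-yl on the shared core

The source may hold more compounds than are shown below. What is called first, only, known or untested is meant among the compounds shown, and "the series" means these compounds.

Measured in an ADME assay on MRC5 cells (Homo sapiens), read by MTT assay, with a stated time of 72 h; on this read-out higher numbers stand for weaker inhibition and lower numbers for stronger inhibition:
- compound 1 `COc1ncnc2c1c(-c1cc3ccccc3o1)cn2[C@@H]1O[C@H](CO)[C@@H](O)[C@H]1O`: 65600 nM
- compound 2 `CNc1ncnc2c1c(-c1ccccc1)cn2[C@@H]1O[C@H](CO)[C@@H](O)[C@H]1O`: > 100000 nM (a limit)

Compound 2 stands only at a limit of > 100000 nM in this assay, with no number of its own (the limit of > 100000 nM in this assay, at which 1 of the 2 values shown sits). Compound 3 `CNc1ncnc2c1c(-c1cc3ccccc3o1)cn2[C@@H]1O[C@H](CO)[C@@H](O)[C@H]1O` carries 1-benzofuran-2-yl in place of phenyl on an aromatic carbon. Within the data shown here, no measured step isolates this change, so the only guide is compound 1, which also carries 1-benzofuran-2-yl and gives 65600 nM. A small step toward stronger inhibition is expected, an at least 1.6-fold lower number from compound 2 to compound 3 (0.22 log units; that floor lies within the scatter). For compound 3 the estimated value is 60000 nM, with an expected range of 20000 nM to 100000 nM.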

Compound 3, half-maximal inhibitory concentration: 75300 nM
Estimate against measurement, compound 3: 1.3-fold (0.10 log units) below; the range from low to high includes it.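

Setting 1-benzofuran-2-yl in place of phenyl on this aromatic carbon gives an at least 1.3-fold lower number from compound 2 to compound 3 (0.12 log units; that floor lies within the scatter) in this assay. Compound 2 has only a limit, so this step is a floor and its full size cannot be read: the limit of > 100000 nM in this assay, at which 1 of the 3 values shown sits. Methylamino in place of methoxy, with 1-benzofuran-2-yl on both compounds, gives a 1.1-fold higher number from compound 1 to compound 3 (0.06 log units; within the scatter) and so does not separate the two groups.

Still open, as far as these compounds go, is whether an amine or a carboxylic acid on the 1-benzofuran-2-yl group, or a longer chain in place of methylamino, would shift the number beyond the scatter.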